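Rat plasma stability: alanine amide to leucine amide

A few compounds are considered here, and "the series" means these few. Any claim that something is new, unique, unknown or untested is made for them only; others in the source may bear on it.

Measured so far in an ADME assay on a cell-free system (plasma, Homo sapiens) for metabolic stability, with Plasma (Rattus norvegicus) as the target, read by HPLC; on this read-out lower numbers stand for a shorter-lived compound and higher numbers for a longer-lived compound:
Compound 1 `COc1cc(NC(C)CCCN2C(=O)CN(C(=O)[C@H](N)CCSC)C2(C)C)c2ncccc2c1` gives > 3 h, a limit of the assay.
Compound 2 `COc1cc(NC(C)CCCN2C(=O)CNC2(C)C)c2ncccc2c1` gives > 3 h, a limit of the assay.
Compound 3 `COc1cc(NC(C)CCCN2C(=O)CN(C(=O)[C@@H](C)N)C2(C)C)c2ncccc2c1` gives > 3 h, a limit of the assay.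

Compound 3 stands where every member of the series stands: all three values sit at the limit of > 3 h in this assay, at which 3 of the 3 values shown sit. None of the three values is a number, so no ordering of the measured compounds can be read from them.

The steps between the measured compounds are accordingly blank: a step that the two limits leave unreadable from compound 1 to compound 2, a step that the two limits leave unreadable from compound 1 to compound 3 and a step that the two limits leave unreadable from compound 2 to compound 3. The last two touch the same region that changes here, the chain carbon two bonds along from the amine nitrogen and the carbonyl carbon, and the amine nitrogen in the ring that carries the acyl group, yet neither gives a readable size.

Compound 4 `COc1cc(NC(C)CCCN2C(=O)CN(C(=O)[C@H](N)CC(C)C)C2(C)C)c2ncccc2c1` differs from compound 3 as follows: isopropyl in place of hydrogen on a saturated chain carbon, two bonds along the chain from an amine nitrogen and a carbonyl carbon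

With every comparable step unreadable and every value at the limit, the expectation for compound 4 in this assay is that it too reaches the limit. The step that the limit leaves unreadable from compound 3 to compound 4 is estimated to be flat within the usual scatter. Compound 4 is expected to give 4.5 h, with a range from 2.5 h to 9 h.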

Compound 4, half-life in the Plasma assay: > 3 h
Compound 4 ended at the assay's limit; the forecaster's own chance of this, stated with the estimate: 75%; the middle value does not contradict the limit.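

Going by these compounds alone, in the Plasma assay compound 4 gives > 3 h, a limit of the assay, so no step between compound 4 and compound 1, compound 2 or compound 3 can be read. In a physicochemical assay for lipophilicity, measured as octanol-water partition (a lower number here means a more polar compound, a higher number a more lipophilic compound), compound 3 gives 2.49 and compound 4 gives 3.36. The compounds shown leave open whether half-life differs at all across the series in the Plasma assay.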